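The source may hold more compounds than are shown below. What is called first, only, known or untested is meant among the compounds shown, and "the series" means these compounds.

Measured so far in a functional assay on the whole organism with Mus musculus as the target, in the rotarod test; a higher number here means that more compound is needed for the effect, a lower number that less compound is needed:

- Compound 1 `NC(=O)/C=C1\CCc2cc(F)c(F)cc21`: 82 mg/kg
- Compound 2 `CC(C)NC(=O)/C=C1\CCc2ccc(F)cc21`: > 100 mg/kg

For compound 2, the entry > 100 mg/kg is a limit of the assay and not a number.

Compound 3 `NC(=O)/C=C1\CCc2ccc(F)cc21` has not yet been measured. It keeps the core of compound 2 and alters one place: hydrogen in place of isopropyl on an amide-type nitrogen. Put simply, hydrogen replaces isopropyl on an amide-type nitrogen, so isopropylamino becomes amino.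

For the measured compounds named here, no measured pair shows this change on its own, which leaves little to go on. The closest guide is compound 1, which also ends in amino and gives 82 mg/kg, a real number rather than a limit. On that basis, compound 3 is expected to return a number too, with a moderate move in this assay towards less compound being needed. A move no larger than the usual scatter remains possible. The expected change is an at least 1.3-fold lower number from compound 2 to compound 3 (0.12 log units; that floor lies within the scatter). For compound 3 the estimate is 75 mg/kg, with an expected range of 35 mg/kg to 150 mg/kg.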

Compound 3, dose for half-maximal effect: 90 mg/kg
Compound 3: the middle estimate sits 1.2-fold (0.08 log units) below what was measured; the range from low to high includes it.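

Replacing isopropyl with hydrogen on the amide-type nitrogen gives a compound with a real number in this assay, and the step can now be written as an at least 1.1-fold lower number from compound 2 to compound 3 (0.04 log units; that floor lies within the scatter). This step has only a floor rather than a full size, and that floor stays within the scatter, because compound 2 is recorded as a limit and not as a number: the limit of > 100 mg/kg in this assay, at which 1 of the 3 values shown sits.

For the compounds shown here, the result also gives a first comparison on an aromatic carbon, where hydrogen takes the place of fluoro: a 1.1-fold higher number from compound 1 to compound 3 (0.04 log units; within the scatter), so in this assay this change cannot be told apart from the scatter on this core.

Whether a methyl or an ethyl on the amide-type nitrogen would give a number or a limit remains open; the compounds shown carry only isopropyl and hydrogen at that place. What a chlorine or a methoxy group would do on that aromatic carbon is open too, with only fluoro and hydrogen shown there.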